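Solubility Along a Spirocycle Swap in a Shared Core

A few compounds are considered here, and "the series" means these few. Any claim that something is new, unique, unknown or untested is made for them only; others in the source may bear on it.

For the measured compounds named here, compound 2, with the structure `COc1ccc2[nH]c(C(=O)N3CC(=O)N(Cc4ccccc4)[C@@H](CN4CCn5cccc5C4)C3)cc2c1`, is the higher of the two numbers measured so far in a physicochemical assay for solubility, read by spectrophotometry, in phosphate buffer, with a stated time of 2 h, at pH 7.4 (on this read-out lower numbers stand for lower solubility and higher numbers for higher solubility), where compound 2 gives 29700 nM. Its nearest neighbour is compound 1, `COc1ccc2[nH]c(C(=O)N3CC(=O)N(Cc4ccccc4)[C@@H](CN4CCC5(CC4)CC5)C3)cc2c1`, which in this assay gives 28200 nM. The step of a 1.1-fold higher number from compound 1 to compound 2 (0.02 log units; within the scatter) is the only one known, and it lies within the usual scatter of repeated measurements.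

The unmeasured compound 3, `COc1ccc2[nH]c(C(=O)N3CC(=O)N(Cc4ccccc4)[C@@H](CN4CCC5(CCCC5)CC4)C3)cc2c1`, departs from compound 2 by one change: a group of 10 heavy atoms (9 carbon, 1 nitrogen; one five-membered non-aromatic ring of carbon only, one six-membered non-aromatic ring with 1 hetero atom) in place of a group of 9 heavy atoms (7 carbon, 2 nitrogen; one five-membered aromatic ring with 1 hetero atom, one six-membered non-aromatic ring with 2 hetero atoms), on a saturated chain carbon bound to a saturated ring carbon. This brings back a spirocyclic amine of the kind seen in compound 1, now with a five-membered carbon ring in place of the three-membered one.

Going by the values given here, the one step that bears on this, from compound 1 to compound 2, was flat, so the move back toward a spirocyclic amine is expected to leave this assay close to where compound 2 stands; the estimated step of a 1.2-fold lower number from compound 2 to compound 3 (0.07 log units; within the scatter) is expected to stay within the scatter. Compound 3 is therefore estimated at 25000 nM, with a range from 12000 nM to 50000 nM.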

Compound 3, solubility: 5000 nM
The estimate for compound 3 lay 5.0-fold (0.70 log units) above the measured number, outside the stated range (below it).
By their numbers in this assay, from the lowest: compound 3; then compounds 1 and 2 (each within the scatter of the next).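

In this assay, for the compounds shown here, the amine on a saturated chain carbon bound to a saturated ring carbon can shift the number after all, since the change gives a 5.9-fold lower number from compound 2 to compound 3 (0.77 log units; beyond the scatter), whereas the only earlier step stayed within the scatter. The closest comparison is between the two spirocyclic amines, where a five-membered carbon ring replaces a three-membered one and the result is a 5.6-fold lower number from compound 1 to compound 3 (0.75 log units; beyond the scatter), so belonging to the spirocyclic kind does not by itself fix the number at this position. No accompanying measurement is available to explain this drop.

With only a three-membered and a five-membered carbon ring in the spirocyclic amines, these compounds cannot show whether the number falls gradually as the ring grows or drops only at the larger ring. A spirocyclic amine with a four-membered carbon ring would fill that gap, and one with an oxygen atom in the five-membered ring would show whether the drop persists when that ring is no longer carbon only.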